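The source may report more compounds than this note shows. Statements on the series, on what has been measured and on what is new or still open speak of the compounds shown alone.

Compound 1, `CC(C)[C@H](NC(=O)COc1cccc2ccccc12)C(=O)N[C@@H](CC(=O)O)C(=O)COc1cc(C(F)(F)F)n(C)n1`, gives 46000 nM in a functional assay on Jurkat cells (Homo sapiens) for inhibition; a lower number here means a stronger inhibitor, a higher number a weaker inhibitor.
Compound 2, `CC(C)c1cc(OCC(=O)[C@H](CC(=O)O)NC(=O)[C@@H](NC(=O)COc2cccc3ccccc23)C(C)C)no1`, gives only a limit of this assay, > 200000 nM.
Compound 3, `CC(C)[C@H](NC(=O)COc1cccc2ccccc12)C(=O)N[C@@H](CC(=O)O)C(=O)CSc1nccn1C`, likewise gives only a limit, > 200000 nM.

Compound 3 therefore stands at the limit of this assay, as does compound 2, and only compound 1 has a number; two of the three values sit there (the limit of > 200000 nM in this assay, at which 2 of the 3 values shown sit). The step under study leads from compound 3 to compound 4, `CC(C)[C@H](NC(=O)COc1cccc2ccccc12)C(=O)N[C@@H](CC(=O)O)C(=O)CSc1nnc(-c2ccccc2)o1`, in which (5-phenyl-1,3,4-oxadiazol-2-yl in place of 1-methyl-1H-imidazol-2-yl on a sulfur). Among the measured compounds shown here, no measured step exchanges one sulfur-linked group for another, so none bears directly on this change. The nearest is an at least 4.3-fold higher number from compound 1 to compound 3 (0.63 log units; beyond the scatter), where the sulfur-linked group entered and the number rose to the limit, while a step that the two limits leave unreadable from compound 2 to compound 3. Because compound 3 gives only the limit > 200000 nM, a further weakening could not be read, and a gain would have to be large before a number appeared. The expected step is an at least 1.3-fold lower number from compound 3 to compound 4 (0.12 log units; that floor lies within the scatter), with the estimate leaning toward another limit. Compound 4 is expected to give about 150000 nM, with a range from 40000 nM to 500000 nM.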

Compound 4, half-maximal inhibitory concentration: 150000 nM
Compound 4: middle estimate and measured number agree at the digits printed, and the stated range covers the measured number.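

In this assay, among the compounds shown here, compound 4 is the first compound with a sulfur-linked group to give a number rather than a limit, and the exchange on the sulfur reads as an at least 1.3-fold lower number from compound 3 to compound 4 (0.12 log units; that floor lies within the scatter). Against the (5-isopropyl-1,2-oxazol-3-yl)oxy group the reading is an at least 1.3-fold lower number from compound 2 to compound 4 (0.12 log units; that floor lies within the scatter), so neither step establishes a real gain, only that the (5-phenyl-1,3,4-oxadiazol-2-yl)sulfanyl group brings the value into the readable range. For the compounds shown here, the one step with a firm size is a 3.3-fold higher number from compound 1 to compound 4 (0.51 log units; beyond the scatter), which leaves the (1-methyl-5-(trifluoromethyl)-1H-pyrazol-3-yl)oxy group ahead, though a sulfur-linked group now has a measured distance from it.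

From the compounds shown here alone, the step between the two compounds still at the limit cannot be read, and how far compound 4 really lies from either of them stays open: the limit of > 200000 nM in this assay, at which 2 of the 4 values shown sit. It also remains open whether the sulfur contributes anything apart from the ring, which an oxygen link to the same 5-phenyl-1,3,4-oxadiazol-2-yl group would test, and whether a methyl group in place of the phenyl, or an amine on the phenyl, would move the number.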